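Removing the ring amine: compound 4 against compound 3

The source may hold more compounds than are shown below. What is called first, only, known or untested is meant among the compounds shown, and "the series" means these compounds.

Measured compounds:
- compound 1, `COc1ccc(Br)cc1CCc1c(F)cccc1C(=O)/N=C(\N)NCCCN1CCCCC1`, 330 nM
- compound 2, `COc1ccc(Br)cc1CCc1c(F)cccc1C(=O)/N=C(\N)NCCCCN1CCCCC1`, 70 nM
- compound 3, `COc1ccc(Br)cc1CCc1c(F)cccc1C(=O)/N=C(\N)NCC1CCNCC1`, 31 nM

All three share one core and differ only in the group on the guanidine-side chain. In a functional assay for antagonist activity at Melanocortin receptor 4 (Homo sapiens), read by cAMP accumulation (a lower number here means a stronger inhibitor, a higher number a weaker inhibitor), compound 3 gives the lowest number of the three; compound 2 stands nearest, and compound 1 furthest, as the steps of a 2.3-fold lower number from compound 2 to compound 3 (0.35 log units; beyond the scatter) and an 11-fold lower number from compound 1 to compound 3 (1.03 log units; beyond the scatter) show. The step of a 4.7-fold lower number from compound 1 to compound 2 (0.67 log units; beyond the scatter) is modest.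

Compound 4, `COc1ccc(Br)cc1CCc1c(F)cccc1C(=O)/N=C(\N)NCC(C)C`, carries the change (isopropyl in place of piperidin-4-yl on a saturated chain carbon bound to an amine nitrogen). The group that leaves has a six-membered non-aromatic ring with one hetero atom, one hydrogen-bond donor and one hydrogen-bond acceptor; isopropyl, which enters, has no ring, no donor and no acceptor. For the measured compounds named here, none of the measured steps removes that ring nitrogen; they only move it or change the spacing to it, and every one of them kept it. The data therefore give no direct guide, and since each measured compound with such a nitrogen sits well, a weaker result seems more likely than a stronger one. Compound 4 is expected to show a step of a 13-fold higher number from compound 3 to compound 4 (1.11 log units; beyond the scatter) in this assay, and its estimated value is 400 nM, ranging from 60 nM to 3000 nM.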

Compound 4, half-maximal inhibitory concentration: 8500 nM
Compound 4: middle estimate off by 21-fold (1.33 log units), on the low side; the whole stated range lies below it.
By their numbers in this assay, from the lowest: compound 3; then compound 2; then compound 1; then compound 4.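

In this assay, isopropyl in place of piperidin-4-yl brings a 270-fold higher number from compound 3 to compound 4 (2.44 log units; beyond the scatter), and this is the first step shown that removes the ring nitrogen rather than moving it, so the position clearly does not tolerate every group. The gap stays large against the two piperidin-1-yl chains, at a 120-fold higher number from compound 2 to compound 4 (2.08 log units; beyond the scatter) and a 26-fold higher number from compound 1 to compound 4 (1.41 log units; beyond the scatter), so all three groups holding a ring nitrogen give far lower numbers than isopropyl. No measurement here accounts for this loss.

This one change removes the ring, the nitrogen and several heavy atoms together, so the compounds shown cannot say which of these matters. A cyclohexyl group, which keeps the ring without the nitrogen, or an open chain ending in a dimethylamino group, which keeps the nitrogen without the ring, would begin to separate them.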